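The source may report more compounds than this note shows. Statements on the series, on what has been measured and on what is new or still open speak of the compounds shown alone.

In a functional assay on B16-F10 cells (Mus musculus) for antiproliferative activity, read by MTT assay, with a stated time of 48 h (on this read-out higher numbers stand for weaker inhibition and lower numbers for stronger inhibition), compound 1 (`COc1ccc(-c2nn(-c3ccccc3)cc2CNc2ccc(Br)cc2)cc1`) gives 8060 nM, the highest of the three numbers available and beyond the scatter from both others. Compound 2 (`Cc1ccc(NCc2cn(-c3ccccc3)nc2-c2ccc(Cl)cc2)cc1`) gives 3480 nM and compound 3 (`Fc1ccc(NCc2cn(-c3ccccc3)nc2-c2ccc(Cl)cc2)cc1`) gives 2120 nM. Compound 4 (`COc1ccc(-c2nn(-c3ccccc3)cc2CNc2ccc(C)cc2)cc1`) keeps the core of compound 1 and carries methyl in place of bromo on an aromatic carbon, methyl in place of bromo on an aromatic carbon. Going by the values given here, the one measured step of this kind, a 1.6-fold lower number from compound 2 to compound 3 (0.22 log units; within the scatter), exchanges methyl for fluoro and stays within the scatter. Among the compounds with values here, no measured pair shows bromo leaving. A change beyond the scatter is therefore not expected in this assay. The expected step is a 1.3-fold lower number from compound 1 to compound 4 (0.13 log units; within the scatter). The estimated value for compound 4 is 6000 nM, with an expected range of 2800 nM to 12000 nM.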

Compound 4, half-maximal inhibitory concentration: 8380 nM
Compound 4: the middle estimate sits 1.4-fold (0.15 log units) below what was measured; the measured number falls inside the stated range.
By their numbers in this assay, from the lowest: compounds 3 and 2 (each within the scatter of the next); then compounds 1 and 4 (each within the scatter of the next).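

In this assay, going by these compounds alone, methyl in place of bromo on the 4-substituted phenylamino group gives a 1.0-fold higher number from compound 1 to compound 4 (0.02 log units; within the scatter), the first reading of bromo leaving, and it shows no change at this position. With that methyl kept, methoxy in place of chloro on an aromatic carbon gives a 2.4-fold higher number from compound 2 to compound 4 (0.38 log units; beyond the scatter), a modest step that the exchange at the bromo position does not match. Nothing measured here accounts for either step. As far as these compounds go, whether an amine or a carboxylic acid at the bromo position would shift the number remains open.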